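Adding a Bromine Beside the Methylsulfanyl Group

The source may hold more compounds than are shown below. What is called first, only, known or untested is meant among the compounds shown, and "the series" means these compounds.

This account follows three measured compounds and one that is still awaiting its number. All were tested in a functional assay on MDA-MB-231 cells (Homo sapiens) for cytotoxicity, read by MTT assay, with a stated time of 48 h; a lower number here means a stronger inhibitor, a higher number a weaker inhibitor. Compound 1 `COc1cc(-c2ocnc2-c2cc(OC)c(OC)c(OC)c2)ccc1SC` gives 850 nM in this assay. Compound 3 `COc1ccc(-c2c(-c3cc(OC)c(SC)c(OC)c3)ncn2C)cc1O` gives 390 nM, a lower number than compound 1, and the gap lies beyond the usual scatter. Compound 2 `COc1ccc(-c2ocnc2-c2cc(Br)c(OC)c(OC)c2)cc1OC`, which carries a bromo group, gives 7830 nM, a higher number than compound 1, again beyond the scatter. Compound 1 therefore sits between these two, closer to compound 3 than to compound 2.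

Compound 4 `COc1cc(-c2ncoc2-c2cc(Br)c(SC)c(OC)c2)cc(OC)c1OC` has not yet been measured. It differs from compound 1 in one way: bromo in place of hydrogen on an aromatic carbon. Among the measured compounds shown here, no measured pair shows exactly this change, so the expected step rests on the wider picture. Because compound 2 gives 7830 nM with a bromo group present, a weakening step is expected in a 2.9-fold higher number from compound 1 to compound 4 (0.47 log units; beyond the scatter), moderate in size and beyond the scatter. Compound 4 is accordingly estimated at 2500 nM, within a range from 800 nM to 8000 nM.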

Compound 4, half-maximal inhibitory concentration: 17900 nM
Compound 4: the middle estimate sits 7.2-fold (0.85 log units) below what was measured; measured number outside the range, above it.
By their numbers in this assay, from the lowest: compound 3; then compound 1; then compound 2; then compound 4.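

In this assay, among the compounds shown here, the step of a 21-fold higher number from compound 1 to compound 4 (1.32 log units; beyond the scatter) is large and gives the first direct reading of this change, since it compares two compounds that differ in one place only. It shows that a single bromine atom, on an aromatic carbon ortho to a methylsulfanyl group and meta to a methoxy group, is enough to weaken the compound this much. Nothing measured here accounts for the size of the step.

Among the compounds shown, bromo is the only replacement for hydrogen at this carbon, so it remains open whether a fluoro group or an amine there would weaken the compound as much, less, or not at all. From the compounds shown here alone, it is also open whether bromo at this carbon would produce a similar step on a compound carrying different groups elsewhere.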